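Oxime ether series: a triazole in place of the alkyne

The compounds below may be only part of what the source reports. "The series", "measured", "known", "first", "only" and "open" are said of these compounds alone.

Measured so far, in a functional assay on MCF7 cells (Homo sapiens) for inhibition, read by sulforhodamine B assay, with a stated time of 48 h, tested at 50 uM; on this read-out lower numbers stand for less inhibition of growth and higher numbers for more inhibition of growth at the one concentration tested:
- Compound 1 `COc1cc2c(cc1CC=C(C)C)C(=O)C[C@@H](c1ccc(Oc3ccc(F)cc3)cc1)O2` gives 37%.
- Compound 2 `C#CCO/N=C1/C[C@@H](c2ccc(OC)cc2)Oc2cc(OC)c(CC=C(C)C)cc21` gives 61%.
- Compound 3 `COc1cc2c(cc1CC=C(C)C)C(=O)C[C@@H](c1ccc(Oc3cccc([N+](=O)[O-])c3)cc1)O2` gives 53%.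

Compound 2 has the highest of the three numbers; the gap to compound 3 lies within the scatter, the gap to compound 1 beyond it. Within the data shown here, the one step with a single change, a number 16 percentage points higher from compound 1 to compound 3 (beyond the scatter), concerns the aryl ether and not the oxime ether.

Compound 4 `COc1ccc([C@@H]2C/C(=N/OCc3cn(-c4ccc(O)cc4)nn3)c3cc(CC=C(C)C)c(OC)cc3O2)cc1` differs from compound 2 by 1-(4-hydroxyphenyl)-1H-1,2,3-triazol-4-yl in place of ethynyl on a saturated chain carbon bound to an oxygen on an unsaturated carbon. No measured step touches this part of the core, so nothing among the shown data bears on the direction; the step of a number 6 percentage points lower from compound 2 to compound 4 (within the scatter) is expected to stay within the scatter. Compound 4 is estimated at 55%, in the range 35% to 75%.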

Compound 4, percent growth inhibition at one concentration: 63%
The estimate for compound 4 lay 8 percentage points below the measured number, within the range that was stated.
By their numbers in this assay, from the lowest: compound 1; then compounds 3, 2 and 4 (each within the scatter of the next).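

At this position, on a saturated chain carbon bound to an oxygen on an unsaturated carbon, 1-(4-hydroxyphenyl)-1H-1,2,3-triazol-4-yl in place of ethynyl gives a number 2 percentage points higher from compound 2 to compound 4 (within the scatter) in this assay. The ethynyl group is therefore not required for a number of this size, and the position accepts a far larger group with two aromatic rings. Nothing available explains this result. Going by these compounds, it remains open whether the hydroxyl on the phenyl ring matters, and whether an amine or a carboxylic acid in its place would keep the number.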